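The source may hold more compounds than are shown below. What is called first, only, known or untested is meant among the compounds shown, and "the series" means these compounds.

Compound 1 `COc1cccc(/C=C2\CCC/C(=C\c3ccc(Cl)cc3)C2=O)c1OC` gives 11100 nM in a functional assay on SW-620 cells (Homo sapiens) for cytotoxicity, read by MTT assay, with a stated time of 72 h; a lower number here means a stronger inhibitor, a higher number a weaker inhibitor. Compound 2 `COc1cccc(/C=C2\CCC/C(=C\c3ccccc3Br)C2=O)c1OC` gives 12100 nM in this assay. Compound 3 `COc1ccc(/C=C2\CCC/C(=C\c3ccc(Cl)cc3)C2=O)cc1OC` gives 5900 nM in this assay.

Compound 1 and compound 3 share the same atoms joined differently; the difference between the two cores is not broken down here. On the core of compound 1, the change 2-bromophenyl in place of 4-chlorophenyl on a double-bonded chain carbon bound to a double-bonded ring carbon gave the step of a 1.1-fold higher number from compound 1 to compound 2 (0.04 log units; within the scatter). Compound 4 `COc1ccc(/C=C2\CCC/C(=C\c3ccccc3Br)C2=O)cc1OC` is not yet measured and carries the same change on the core of compound 3, (2-bromophenyl in place of 4-chlorophenyl on a double-bonded chain carbon bound to a double-bonded ring carbon).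

Among the compounds with values here, only one earlier example of this change exists, so the expectation for compound 4 rests on it alone. Because compound 1 to compound 2 gave a 1.1-fold higher number from compound 1 to compound 2 (0.04 log units; within the scatter), compound 4 is expected to differ from compound 3 by about a 1.1-fold higher number from compound 3 to compound 4 (0.04 log units; within the scatter). Compound 4 is therefore estimated at 6500 nM, likely between 3000 nM and 14000 nM.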

Compound 4, half-maximal inhibitory concentration: 5300 nM
Beside the measured number, compound 4's estimate is 1.2-fold (0.09 log units) above it, and the stated range covers the measured number.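

On the second core, 2-bromophenyl in place of 4-chlorophenyl gave a 1.1-fold lower number from compound 3 to compound 4 (0.05 log units; within the scatter) in this assay. The two examples of this change agree: the same change on two cores in this assay, a 1.1-fold higher number (0.04 log units; within the scatter) from compound 1 to compound 2 and a 1.1-fold lower number (0.05 log units; within the scatter) from compound 3 to compound 4, 1.2-fold (0.08 log units) apart, within the scatter of two such steps. On these two cores, then, the change makes no readable difference to the number, but two pairs do not show that this would hold on other cores, and they cannot separate the effect of swapping the halogen from that of moving it.

Only chlorine and bromine on the phenyl ring appear at this place in the compounds shown. From the compounds shown here alone, what an amine or a carboxylic acid on that ring would do, and whether such a step would carry from one core to the other, stays open.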